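A few compounds are considered here, and "the series" means these few. Any claim that something is new, unique, unknown or untested is made for them only; others in the source may bear on it.

Compound 1 `COc1ccc(-c2cc(-c3ccc(S(N)(=O)=O)cc3)cnc2N)cn1`: in a physicochemical assay for solubility, read by nephelometry, measured as kinetic solubility, at pH 2 (on this read-out lower numbers stand for lower solubility and higher numbers for higher solubility), compound 1 gives > 100 ug/mL, which is a limit of the assay.
Compound 2 `COc1ccc(-c2cc(-c3ccc(S(=O)(=O)NC4CC4)cc3)cnc2N)cn1`: in this assay compound 2 gives > 100 ug/mL, which is a limit of the assay.
Compound 3 `COc1ccc(-c2cc(-c3ccc(S(C)(=O)=O)cc3C(F)(F)F)cnc2N)cn1`: in this assay compound 3 gives > 100 ug/mL, which is a limit of the assay.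

Compound 2 therefore stands at a limit rather than at a number, and it shares that position with every other compound measured here, since (the limit of > 100 ug/mL in this assay, at which 3 of the 3 values shown sit). Among the compounds with values here, the one step that joins two measured compounds, a step that the two limits leave unreadable from compound 1 to compound 2, is the exchange of cyclopropyl in place of hydrogen on a sulfonamide nitrogen, and the two limits leave its size unreadable.

The new compound is compound 4 `COc1ccc(-c2cc(-c3ccc(-n4cccn4)cc3)cnc2N)cn1`. It differs from compound 2 as follows: 1H-pyrazol-1-yl in place of cyclopropylsulfamoyl on an aromatic carbon. In words, 1H-pyrazol-1-yl takes the place of cyclopropylsulfamoyl on an aromatic carbon. Within the data shown here, no measured step touches this kind of exchange, and the single step that is known gives no size, so no direction can be read from the data. The expectation is that the step of an at least 1.1-fold lower number from compound 2 to compound 4 (0.04 log units; that floor lies within the scatter) stays close to where compound 2 sits. Compound 4 is therefore estimated at 90 ug/mL in this assay, with a range from 25 ug/mL to 200 ug/mL.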

Compound 4, solubility: > 100 ug/mL
Compound 4 gave a limit, no number (the forecaster's own chance of this, stated with the estimate: 55%); middle value at least 1.1-fold (0.04 log units) from the limit.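

Compound 4 also gives a limit rather than a number, so the steps linking it to compound 1 and compound 2 cannot be read: the limit of > 100 ug/mL in this assay, at which 4 of the 4 values shown sit. The compounds shown leave open whether any of these exchanges shifts the read-out in this assay, and by how much.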